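Adding a chloro group to the phenyl of compound 2

The compounds below may be only part of what the source reports. "The series", "measured", "known", "first", "only" and "open" are said of these compounds alone.

Measured so far:
Compound 1 `O=C(N[C@H]1CN(S(=O)(=O)c2ccccc2)C[C@@H]1C(=O)N[C@H]1CCCNC1)c1cc(C2CC2)n[nH]1`: 0.2
Compound 2 `O=C(N[C@H]1CN(S(=O)(=O)c2ccccc2)C[C@@H]1C(=O)N[C@H]1CCCNC1)c1cc(-c2ccccc2)on1`: 1.3

In a physicochemical assay for lipophilicity, measured as octanol-water partition, at pH 7.4 (a lower number here means a more polar compound, a higher number a more lipophilic compound), compound 2, at 1.3, holds the higher of the two numbers, clearly beyond the scatter from compound 1. Compound 3 `O=C(N[C@H]1CN(S(=O)(=O)c2ccccc2)C[C@@H]1C(=O)N[C@H]1CCCNC1)c1cc(-c2ccc(Cl)cc2)on1` is compound 2 with one change: chloro in place of hydrogen on an aromatic carbon. This is chloro in place of hydrogen on an aromatic carbon, para to a large group, turning phenyl into 4-chlorophenyl.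

Within the data shown here, only one measured step exists: a number 1.10 log units higher from compound 1 to compound 2 (beyond the scatter). Among the measured compounds shown here, that large step exchanged the whole group on the carbonyl carbon, so it bears only loosely on a single added chloro, and no measured pair shows this change directly. The estimated step is a number 0.60 log units higher from compound 2 to compound 3 (beyond the scatter), expected to be upward, beyond the scatter and smaller than the measured one. For compound 3 the expected value in this assay is 1.9, with an estimated range of 1.5 to 2.3.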

Compound 3, distribution coefficient: 2.1
For compound 3 the middle estimate is 0.20 log units below the measured one; low and high end bracket the measured number.
By their numbers in this assay, from the lowest: compound 1; then compound 2; then compound 3.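

In this assay, the earlier step exchanged the whole group on the carbonyl carbon, whereas this one isolates a single atom on the phenyl: chloro in place of hydrogen gives a number 0.80 log units higher from compound 2 to compound 3 (beyond the scatter) on its own. Set against the exchange that leads to the 4-chlorophenyl compound, which gives a number 1.90 log units higher from compound 1 to compound 3 (beyond the scatter) across the series, this shows that the outer phenyl is a place where one added atom moves the number beyond the scatter. Nothing measured here accounts for the size of this step.

The compounds shown leave open whether fluoro, methoxy or an amine on the same aromatic carbon would move the number in the same direction. They also leave open whether chloro would give a similar step on the pyrazole-bearing compound 1.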